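A few compounds are considered here, and "the series" means these few. Any claim that something is new, unique, unknown or untested is made for them only; others in the source may bear on it.

Measured so far in a functional assay on OVCAR-4 cells (Homo sapiens) for inhibition, read by sulforhodamine B assay, with a stated time of 48 h; a higher number here means a weaker inhibitor of growth, a lower number a stronger inhibitor of growth:
compound 1 `CCCCOc1ccc(NC(=O)n2nc(N)c3ccccc32)cc1` gives 30700 nM
compound 2 `Nc1nn(C(=O)Nc2c(F)cccc2F)c2ccccc12` gives 57800 nM

Compound 1 has the lower of the two numbers, yet compound 2 sits within the scatter of it, so no order between them can be read. Compound 3 `Nc1nn(C(=O)Nc2ccc(Cc3ccccc3)cc2)c2ccccc12` is not yet measured. It differs from compound 1 as follows: benzyl in place of butoxy on an aromatic carbon. Among the measured compounds shown here, no step between measured compounds exists that resembles this change, so its size cannot be taken from the data. In this assay no step beyond the scatter is expected for compound 3, the estimated step being a 1.2-fold lower number from compound 1 to compound 3 (0.09 log units; within the scatter). Compound 3 is accordingly estimated at 25000 nM, with a range from 8000 nM to 80000 nM.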

Compound 3, concentration for 50% growth inhibition: 10700 nM
The estimate for compound 3 lay 2.3-fold (0.37 log units) above the measured number; low and high end bracket the measured number.
By their numbers in this assay, from the lowest: compound 3; then compounds 1 and 2 (each within the scatter of the next).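

In this assay, among the compounds shown here, benzyl in place of butoxy on an aromatic carbon, para to a large group, gives a 2.9-fold lower number from compound 1 to compound 3 (0.46 log units; beyond the scatter) and is the first step beyond the scatter. This position therefore responds to the group it carries, and a chain can give way to a ring of carbon only with a modest gain in growth inhibition. Nothing at hand accounts for the size of this step.

Open, on these data alone, is how phenoxy, phenyl or a longer alkoxy chain at this position would compare with benzyl. Also open, as far as these compounds go, is whether an amine there would keep the gain seen with compound 3.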